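Moving a carbamoyl from para to ortho on an aryl azo core

The source may report more compounds than this note shows. Statements on the series, on what has been measured and on what is new or still open speak of the compounds shown alone.

Measured compounds:
compound 1 `CN(C)/N=N/c1ccc(C(N)=O)cc1`, 1.2
compound 2 `CN(C)/N=N/c1ccccc1Cl`, 2.97
compound 3 `CN(C)/N=N/c1ccc(Cl)cc1`, 3.3

Of the compounds shown here, three have been measured in a physicochemical assay for lipophilicity (on this read-out higher numbers stand for higher lipophilicity and lower numbers for lower lipophilicity), and one more, compound 4 `CN(C)/N=N/c1ccccc1C(N)=O`, is waiting for its number. Compound 3 and compound 2 share the same atoms, joined differently; the difference between the two cores is not broken down here. In this assay compound 3 gives 3.3 and compound 2 gives 2.97, a gap beyond the scatter. Compound 1 gives 1.2, the lowest of the three.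

The step from compound 3 to compound 1 is carbamoyl in place of chloro on an aromatic carbon and it moved this assay by a number 2.10 log units lower from compound 3 to compound 1 (beyond the scatter). The step from compound 2 to compound 4 is carbamoyl in place of chloro on an aromatic carbon. It is the same kind of change, but the place differs: in the earlier pair the carbamoyl stands para to a group of 5 heavy atoms, in the new pair ortho to a group of 5 heavy atoms. The change has occurred once among the measured compounds. Going by the values given here, compound 4 is therefore expected to fall by about a number 1.97 log units lower from compound 2 to compound 4 (beyond the scatter) in this assay, resting on the single earlier step, which carries the size a number 2.10 log units lower from compound 3 to compound 1 (beyond the scatter), with wider uncertainty because only one example exists and its place differs. For compound 4 the estimate is 1, between 0.4 and 1.6.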

Compound 4, partition coefficient: 1.73
Beside the measured number, compound 4's estimate is 0.73 log units below it; measured number above the stated range.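

In this assay the exchange of chloro for carbamoyl again lowers the number, with a number 1.24 log units lower from compound 2 to compound 4 (beyond the scatter) set against the earlier a number 2.10 log units lower from compound 3 to compound 1 (beyond the scatter) in the same direction, so the direction of the change carries from one core to the other while its size does not carry over in full. With only these two pairs, and with the carbamoyl in the new pair ortho to a group of 5 heavy atoms while the earlier pair has it in a different place, the result shows that both steps are large but does not show how far the smaller size belongs to the place of the group and how far to anything else about the core. Nothing available bears on why the second step is the smaller one.

The compounds shown leave open whether an amine or a carboxylic acid in place of chloro would lower the number on both cores in the same way. They also leave open whether a nitrile or a methyl ester would follow carbamoyl on these cores.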